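This account rests on a few compounds, and the source may have more. Where it says the series, first, only, none or still open, it means among the compounds named here.

In a functional assay on NCI-H520 cells (Homo sapiens) for inhibition, read by MTT assay, with a stated time of 48 h, tested at 10 uM (a higher number here means more inhibition at the concentration tested (going by the name of the read-out), a lower number less inhibition), two compounds sharing one core have been measured. Compound 1 `COc1cc(NC(=O)Nc2cc(Nc3ccc(C(C)(C)C)cc3)ncn2)cc(OC)c1` gives 17.5%, and compound 2 `COc1cc(NC(=O)Nc2cc(Nc3ccc(Br)cc3OC)ncn2)cc(OC)c1` gives 36.1%. Going by the values given here, compound 2 therefore stands highest of the two numbers, with compound 1 as its only neighbour. Among the compounds with values here, the single measured step, a number 18.6 percentage points higher from compound 1 to compound 2 (beyond the scatter), shows that swapping the group on the nitrogen on the aromatic ring can shift inhibition by a modest amount.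

Compound 3 `COc1cc(NC(=O)Nc2cc(Nc3cc(C)cc(F)c3)ncn2)cc(OC)c1` differs from compound 2 at that same place: 3-fluoro-5-methylphenyl in place of 4-bromo-2-methoxyphenyl on a nitrogen on an aromatic ring. Within the data shown here, no measured step compares these two groups directly, so the step of a number 18.6 percentage points higher from compound 1 to compound 2 (beyond the scatter) is the only guide; it suggests a change of modest size at this position, with no clear direction for this pair. A modest downward step a number 10.1 percentage points lower from compound 2 to compound 3 (beyond the scatter) is expected, landing compound 3 between its two neighbours. Compound 3 is estimated at 26%, within a range from 9% to 44%.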

Compound 3, a percentage reported as inhibition, at one concentration (the size of the read-out at that concentration, not a potency): 24.5%
The estimate for compound 3 lay 1.5 percentage points above the measured number; the range from low to high includes it.
By their numbers in this assay, from the lowest: compounds 1 and 3 (each within the scatter of the next); then compound 2.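

In this assay, using 3-fluoro-5-methylphenyl in place of 4-bromo-2-methoxyphenyl gives a number 11.6 percentage points lower from compound 2 to compound 3 (beyond the scatter), so 4-bromo-2-methoxyphenyl now stands clear of two other groups at this nitrogen, not just 4-(tert-butyl)phenyl. Using 3-fluoro-5-methylphenyl in place of 4-(tert-butyl)phenyl gives a number 7 percentage points higher from compound 1 to compound 3 (within the scatter), so these two groups cannot be ranked against each other in this assay, and not every change at this position moves the number measurably. Nothing available explains these differences.

The compounds shown leave open whether the bromine or the methoxy group of compound 2 matters more, since the two are never varied separately. They also leave open how this position would respond to a phenyl ring carrying a carboxylic acid or a morpholine.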